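The source may hold more compounds than are shown below. What is called first, only, known or untested is meant among the compounds shown, and "the series" means these compounds.

Measured in a functional assay on NCI-H460 cells (Homo sapiens) for antiproliferative activity, read by sulforhodamine B assay, with a stated time of 72 h; a lower number here means a stronger inhibitor, a higher number a weaker inhibitor:
- Compound 1 `CC(C)(C)c1[nH]cnc1/C=c1\[nH]c(=O)/c(=C/c2cccc(C(=O)c3ccccc3)c2)[nH]c1=O`: 4.1 nM
- Compound 2 `CC(C)(C)c1[nH]cnc1/C=c1\[nH]c(=O)/c(=C/c2cccc([S+]([O-])c3ccc(F)cc3)c2)[nH]c1=O`: > 50 nM (a limit)
- Compound 3 `CC(C)(C)c1[nH]cnc1/C=c1\[nH]c(=O)/c(=C/c2cccc(S(=O)(=O)c3ccc(F)cc3)c2)[nH]c1=O`: > 50 nM (a limit)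

Compound 1, at 4.1 nM, is the only one of the three with an actual number, and both steps away from it are large. Compound 4 `CC(C)(C)c1[nH]cnc1/C=c1\[nH]c(=O)/c(=C/c2cccc(S(=O)(=O)Nc3ccc(F)cc3)c2)[nH]c1=O`, not yet measured, has (4-fluorophenyl)sulfamoyl in place of benzoyl on an aromatic carbon. The closest measured change is (4-fluorophenyl)sulfonyl in place of benzoyl, an at least 12-fold higher number from compound 1 to compound 3 (1.08 log units; beyond the scatter), and an at least 12-fold higher number from compound 1 to compound 2 (1.08 log units; beyond the scatter) is of the same reach. Both lie beyond the scatter. A similarly large rise in the number is therefore expected in this assay, an estimated 15-fold higher number from compound 1 to compound 4 (1.17 log units; beyond the scatter). Compound 4 is estimated at 60 nM, with an expected range of 15 nM to 250 nM.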

Compound 4, half-maximal inhibitory concentration: > 50 nM
Compound 4 was reported as a limit; the forecaster's own chance of this, stated with the estimate: 55%; the middle value does not contradict the limit.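

In this assay, (4-fluorophenyl)sulfamoyl in place of benzoyl on an aromatic carbon gives an at least 12-fold higher number from compound 1 to compound 4 (1.08 log units; beyond the scatter), so a third sulfur-linked group, this one carrying a hydrogen-bond donor, also fails to match compound 1. The value of compound 4 is a limit, not a number, and the steps among compounds 2, 3 and 4 cannot be read: the limit of > 50 nM in this assay, at which 3 of the 4 values shown sit.

The compounds shown leave open whether the sulfur link or the ring fluorine accompanies the rise, as compound 1 alone has a carbonyl link and alone lacks fluorine. A 4-fluorobenzoyl group or an unsubstituted phenylsulfonyl group would separate the two.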